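The source may hold more compounds than are shown below. What is called first, only, known or untested is meant among the compounds shown, and "the series" means these compounds.

Compound 1 `CC1=CC[C@H](C(C)C)c2cc(C)c(OC(=O)c3ccc(C)cc3)cc21` opens the set; in a functional assay on MCF7 cells (Homo sapiens) for antiproliferative activity, read by sulforhodamine B assay, with a stated time of 48 h, tested at 50 uM (a lower number here means less inhibition, a higher number more inhibition at the concentration tested (going by the name of the read-out)), compound 1 gives 65%. Compound 2 `Cc1cc2c(C(C)C)ccc(C)c2cc1OC(=O)c1cccc(C(F)(F)F)c1` gives 41.5% in this assay. Compound 3 `CC1=CC[C@H](C(C)C)c2cc(C)c(OC(=O)c3ccc(C(F)(F)F)cc3)cc21` gives 40.4% in this assay, the lowest of the three numbers; its gap to compound 2 lies within the scatter, while its gap to compound 1 lies beyond it. Within the data shown here, the one measured step that changes a single place runs a number 24.6 percentage points lower from compound 1 to compound 3 (beyond the scatter), a modest loss.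

Compound 4 `COc1ccc(C(=O)Oc2cc3c(cc2C)[C@@H](C(C)C)CC=C3C)cc1` follows from compound 3 by methoxy in place of trifluoromethyl on an aromatic carbon, at the aromatic carbon where compound 1 carries methyl and compound 3 carries trifluoromethyl. Among the measured compounds shown here, the step from compound 1 to compound 3 is the only measured step bearing on this change, and it shows that exchanging the group at this carbon moves the number beyond the scatter. With trifluoromethyl leaving again, compound 4 is expected to recover part of that loss, a step estimated at a number 16.6 percentage points higher from compound 3 to compound 4 (beyond the scatter). The estimate for compound 4 in this assay is 57%, with a range from 40% to 74%.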

Compound 4, a percentage reported as inhibition, at one concentration (the size of the read-out at that concentration, not a potency): 80.1%
Compound 4: middle estimate off by 23.1 percentage points, on the low side; the whole stated range lies below it.
By their numbers in this assay, from the lowest: compounds 3 and 2 (each within the scatter of the next); then compound 1; then compound 4.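

At the aromatic carbon para to a large group, the number in this assay can rise as well as fall: methoxy in place of methyl gives a number 15.1 percentage points higher from compound 1 to compound 4 (beyond the scatter), so this carbon is not limited to the loss seen earlier with trifluoromethyl. Methoxy in place of trifluoromethyl gives a number 39.7 percentage points higher from compound 3 to compound 4 (beyond the scatter), a larger move than either step involving methyl, which places methyl between the other two groups across these three compounds. Nothing measured here accounts for this order.

Going by these compounds, whether the gain is specific to methoxy stays open, as an ethoxy group, a hydroxyl or an amine at this carbon would be needed to show how far it extends. Each reading also comes from a single concentration, so the order of these compounds says nothing about their potency.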